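This account rests on a few compounds, and the source may have more. Where it says the series, first, only, none or still open, it means among the compounds named here.

Compound 1 `CC(=O)N[C@@H]1CCN(c2cc(C)nn3c(-c4ccco4)c(C)nc23)C1` in an ADME assay on microsomes from liver (Mus musculus) for metabolic stability, read by LC-MS, with NADPH named in the record, with a stated time of 60 min, tested at 1 uM, in the absence of a further agent; on this read-out higher numbers stand for a more stable compound and lower numbers for a less stable compound: > 95%
Compound 2 `CCCCCC(=O)N[C@@H]1CCN(c2cc(C)nn3c(-c4ccc(OC)c(OC)c4)c(C)nc23)C1` in this assay: > 95%

Compound 2 stands at the limit of > 95% in this assay, at which 2 of the 2 values shown sit, so its reading is a limit of the assay and not a number. Compound 1 shares that same limit, and the two compounds therefore cannot be ranked against each other. The next compound to be tested is compound 3 `COc1ccc(-c2c(C)nc3c(N4CC[C@@H](NS(=O)(=O)C(C)C)C4)cc(C)nn23)cc1OC`. It keeps the core and the substituents of compound 2 and changes one group: isopropylsulfonyl in place of pentylcarbonyl on an amine nitrogen. Thus isopropylsulfonyl stands in place of pentylcarbonyl on an amine nitrogen. Among the compounds with values here, no pair of measured compounds differs in a single place, so the data offer no direct step for this change. The expectation rests only on (the limit of > 95% in this assay, at which 2 of the 2 values shown sit), shared by compound 1 and compound 2. In this assay, the estimated step of a number at least 2 percentage points lower from compound 2 to compound 3 (that floor lies within the scatter) is expected to stay within the usual scatter, with any shift more likely downward, since the reading cannot rise far. For compound 3 the estimated value is 93%, with an expected range from 80% to 100%.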

Compound 3, percent of the compound remaining: > 95%
Compound 3 gave a limit, no number; the forecaster's own chance of this, stated with the estimate: 55%; middle value at least 2 percentage points from the limit.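

In this assay compound 3 gives > 95%, a limit of the assay and not a number. Within the data shown here, no step from compound 2 to compound 3 can be read, because both readings sit at the same limit: the limit of > 95% in this assay, at which 3 of the 3 values shown sit. The compounds shown leave open whether isopropylsulfonyl in place of pentylcarbonyl on an amine nitrogen changes the stability at all.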